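The source may report more compounds than this note shows. Statements on the series, on what has been measured and on what is new or still open speak of the compounds shown alone.

Measured so far:
compound 1 `ClCc1ccc(Cn2cnc3c(Cl)ncnc32)cc1` — 21900 nM
compound 2 `ClCc1cccc(Cn2cnc3ncnc(Cl)c32)c1` — "not determined" (no result reported)
compound 3 `ClCc1ccc(Cn2cnc3c(Cl)nc(Cl)nc32)cc1` — 7080 nM

In a functional assay on SNB-19 cells (Homo sapiens) for cytotoxicity, read by sulforhodamine B assay, with a stated time of 48 h (on this read-out lower numbers stand for stronger inhibition of growth and higher numbers for weaker inhibition of growth), compound 1 gives 21900 nM and compound 3 gives 7080 nM. The change from compound 1 to compound 3 is chloro in place of hydrogen on an aromatic carbon and made a 3.1-fold lower number from compound 1 to compound 3 (0.49 log units; beyond the scatter). Compound 2 carries a second core; the difference between the two cores is not broken down here, and compound 2 has no number in this assay.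

Compound 4 `ClCc1cccc(Cn2cnc3nc(Cl)nc(Cl)c32)c1` follows from compound 2 by chloro in place of hydrogen on an aromatic carbon, the same change as that from compound 1 to compound 3. In this assay a step of similar size to a 3.1-fold lower number from compound 1 to compound 3 (0.49 log units; beyond the scatter) is expected for compound 2 to compound 4, resting on that single measured pair alone. Because compound 2 has no value, the expectation is anchored on compound 3 instead. Compound 4 is expected at about 9000 nM, estimated between 3000 nM and 30000 nM.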

Compound 4, concentration for total growth inhibition: 2690 nM
Compound 4: the middle estimate sits 3.3-fold (0.52 log units) above what was measured; measured number below the stated range.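

No new step can be read for compound 4, as compound 2 has no single number in this assay. The compounds shown leave open whether chloro in place of hydrogen on this core matches the step of a 3.1-fold lower number from compound 1 to compound 3 (0.49 log units; beyond the scatter). No evidence bearing on this result is available.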